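Replacing Benzyloxy with Diethylamino on a Shared Core

The source may report more compounds than this note shows. Statements on the series, on what has been measured and on what is new or still open speak of the compounds shown alone.

In a functional assay on HeLa cells (Homo sapiens) for cytotoxicity, read by MTT assay, with a stated time of 72 h (on this read-out lower numbers stand for stronger inhibition and higher numbers for weaker inhibition), compound 3 `O=C(NCCO)c1cc2ccc(OCc3ccccc3)cc2oc1=O` gives 14200 nM. It stands at the low end of the two numbers, with compound 2 `CCCOc1ccc2cc(C(=O)NCCO)c(=O)oc2c1` nearest at 22600 nM, and the step of a 1.6-fold lower number from compound 2 to compound 3 (0.20 log units; within the scatter) is within the scatter. Compound 1 `CCOc1ccc2cc(C(=O)NCCO)c(=O)oc2c1` reaches only the assay limit of > 100000 nM. The steps of an at least 4.4-fold lower number from compound 1 to compound 2 (0.64 log units; beyond the scatter) and an at least 7.0-fold lower number from compound 1 to compound 3 (0.84 log units; beyond the scatter) show that a longer or larger chain on the ether oxygen lowers the number.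

Compound 4 `CCN(CC)c1ccc2cc(C(=O)NCCO)c(=O)oc2c1` differs from compound 3 by diethylamino in place of benzyloxy on an aromatic carbon. Among the compounds with values here, no measured step swaps the ether oxygen itself, so none bears directly on this change; the measured steps only vary the chain on that oxygen. The entering group is smaller than the benzyloxy that leaves, which is comparable to the propoxy of compound 2. Compound 4 is therefore expected at about 30000 nM, between 8000 nM and 100000 nM, a step of a 2.1-fold higher number from compound 3 to compound 4 (0.32 log units; beyond the scatter).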

Compound 4, half-maximal inhibitory concentration: > 100000 nM
Compound 4 gave a limit, no number (the forecaster's own chance of this, stated with the estimate: 30%); middle value at least 3.3-fold (0.52 log units) away from the limit.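

In this assay compound 4 gives only a limit, > 100000 nM, not a number. Unlike the steps that vary the chain on the ether oxygen, this change replaces the oxygen itself, and diethylamino in place of benzyloxy gives an at least 7.0-fold higher number from compound 3 to compound 4 (0.84 log units; beyond the scatter), while diethylamino in place of propoxy gives an at least 4.4-fold higher number from compound 2 to compound 4 (0.64 log units; beyond the scatter). The step between compound 1 and compound 4 cannot be read, as both values are limits: the limit of > 100000 nM in this assay, at which 2 of the 4 values shown sit.

The compounds shown leave open whether benzylamino, or a longer chain on the nitrogen in place of the ethyl groups, would give a readable number on this aromatic carbon.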